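A Nitro Group Meets a Cytotoxicity Limit

This account rests on a few compounds, and the source may have more. Where it says the series, first, only, none or still open, it means among the compounds named here.

Of the compounds shown here, three sharing one core have been tested in a functional assay on HepG2 cells (Homo sapiens) for cytotoxicity, read by MTT assay, with a stated time of 48 h; on this read-out lower numbers stand for stronger inhibition and higher numbers for weaker inhibition. Compound 1 `COc1cc(-c2nnc3n2NC(c2ccco2)C(C(=O)c2ccccc2C)S3)cc(OC)c1OC` carries a 2-methylphenyl on a carbonyl carbon, and in this assay compound 1 gives 63000 nM. Compound 2 `COc1cc(-c2nnc3n2NC(c2ccco2)C(C(=O)c2ccccc2F)S3)cc(OC)c1OC` differs from it only by fluoro in place of methyl on an aromatic carbon. In this assay compound 2 reaches only a limit of the assay, > 100000 nM. Compound 3 `COc1cc(-c2nnc3n2NC(c2ccco2)C(C(=O)C2CC2)S3)cc(OC)c1OC` has cyclopropyl in place of 2-methylphenyl on a carbonyl carbon. In this assay compound 3 likewise stops at an assay limit, > 100000 nM. The step from compound 1 to compound 2 is an at least 1.5-fold higher number from compound 1 to compound 2 (0.20 log units; that floor lies within the scatter), the step from compound 1 to compound 3 is an at least 1.5-fold higher number from compound 1 to compound 3 (0.20 log units; that floor lies within the scatter), and the step from compound 2 to compound 3 is a step that the two limits leave unreadable from compound 2 to compound 3. Compound 4 `COc1cc(-c2nnc3n2NC(c2ccco2)C(C(=O)c2ccc([N+](=O)[O-])cc2)S3)cc(OC)c1OC` is not yet measured; it has 4-nitrophenyl in place of 2-fluorophenyl on a carbonyl carbon. The measured steps at this position leave the direction open, and because the limit of > 100000 nM in this assay, at which 2 of the 3 values shown sit, catches two of the three values, another limit rather than a number is the likeliest outcome. The step from compound 2 to compound 4 is expected to be a number no higher from compound 2 to compound 4 (the limit leaves the size open). Compound 4 is therefore estimated at 100000 nM, within a range of 40000 nM to 300000 nM.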

Compound 4, half-maximal inhibitory concentration: 87800 nM
Compound 4: middle estimate off by 1.1-fold (0.06 log units), on the high side; the measured number falls inside the stated range.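

Within the data shown here, compound 4 shows that 2-methylphenyl is not the only group on this carbonyl carbon to give a real number in this assay, since 4-nitrophenyl gives one too. Set against the two limits, the readings are an at least 1.1-fold lower number from compound 2 to compound 4 (0.05 log units; that floor lies within the scatter) and an at least 1.1-fold lower number from compound 3 to compound 4 (0.05 log units; that floor lies within the scatter), so neither step stands clear of the scatter, and the comparison with the other measured number is a 1.4-fold higher number from compound 1 to compound 4 (0.14 log units; within the scatter), which leaves compound 1 and compound 4 indistinguishable. Compound 2 and compound 3 remain at a limit of the assay, not a number: the limit of > 100000 nM in this assay, at which 2 of the 4 values shown sit.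

The compounds shown leave open how far the true values of compound 2 and compound 3 lie from the two measured numbers, and whether any group at this place can move the number beyond the scatter. An amine or a carboxylic acid on the phenyl ring in place of the nitro group, or a longer chain in place of cyclopropyl, would put that question to the test.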